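Replacing (4-chlorophenyl)amino with piperidin-1-yl: working notes

The compounds below may be only part of what the source reports. "The series", "measured", "known", "first", "only" and "open" are said of these compounds alone.

Measured in a functional assay on MDA-MB-231 cells (Homo sapiens) for inhibition, with a stated time of 72 h; on this read-out lower numbers stand for stronger inhibition and higher numbers for weaker inhibition:
compound 1 `O=C(Nc1ccccc1)Nc1nc(NC2CC2)cc(Sc2c[nH]c3ccccc23)n1`: 7860 nM
compound 2 `O=C(Nc1ccc(Cl)cc1)Nc1nc(Sc2c[nH]c3ccccc23)cc(N2CCCCC2)n1`: 10100 nM
compound 3 `O=C(Nc1ccccc1)Nc1nc(Nc2ccc(Cl)cc2)cc(Sc2c[nH]c3ccccc23)n1`: 10300 nM

Compound 3 lies within the scatter of both compound 1 and compound 2. The next structure, compound 4 `O=C(Nc1ccccc1)Nc1nc(Sc2c[nH]c3ccccc23)cc(N2CCCCC2)n1`, carries piperidin-1-yl in place of (4-chlorophenyl)amino on an aromatic carbon. Among the measured compounds shown here, one measured step bears on this place, a 1.3-fold higher number from compound 1 to compound 3 (0.12 log units; within the scatter), with 4-chlorophenyl in place of cyclopropyl on a nitrogen. Compound 2 also carries piperidin-1-yl and gives 10100 nM. No step beyond the scatter is therefore expected in this assay. The estimated step is a 1.1-fold lower number from compound 3 to compound 4 (0.04 log units; within the scatter). The expected value for compound 4 is 9500 nM, within an estimated range of 4500 nM to 20000 nM.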

Compound 4, half-maximal inhibitory concentration: 8130 nM
Estimate against measurement, compound 4: 1.2-fold (0.07 log units) above; the measured number falls inside the stated range.
By their numbers in this assay, from the lowest: compounds 1, 4, 2 and 3 (each within the scatter of the next).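

In this assay this aromatic carbon tolerates a saturated ring on nitrogen as well as an aromatic one: piperidin-1-yl in place of (4-chlorophenyl)amino (a 1.3-fold lower number from compound 3 to compound 4 (0.10 log units; within the scatter)) and in place of cyclopropylamino (a 1.0-fold higher number from compound 1 to compound 4 (0.01 log units; within the scatter)) both stay within the scatter, even though the piperidin-1-yl group has no hydrogen-bond donor. With piperidin-1-yl held, hydrogen in place of chloro on the phenyl urea also stays within the scatter (a 1.2-fold lower number from compound 2 to compound 4 (0.09 log units; within the scatter)). No measured evidence explains these steps.

On these data alone, whether an amine-bearing chain, a carboxylic acid or morpholin-4-yl at this place would move the number beyond the scatter stays open.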